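The compounds below may be only part of what the source reports. "The series", "measured", "known", "first", "only" and "open" are said of these compounds alone.

Measured so far:
compound 1 `O=C(Nc1ccccc1)N(Cc1ccccn1)n1cnnc1`: > 50000 nM
compound 2 `O=C(NC1CCCCC1)N(Cc1ccccn1)n1cnnc1`: 44100 nM

In a functional assay on MDA-MB-231 cells (Homo sapiens) for cytotoxicity, read by MTT assay, with a stated time of 48 h (a higher number here means a weaker inhibitor, a lower number a stronger inhibitor), compound 1 reaches only a limit of the assay, not a number (the limit of > 50000 nM in this assay, at which 1 of the 2 values shown sits). For the measured compounds named here, the one measured step, an at least 1.1-fold lower number from compound 1 to compound 2 (0.05 log units; that floor lies within the scatter), concerns a different place in the molecule and lies within the scatter. Compound 3 `Cc1ccsc1CN(C(=O)Nc1ccccc1)n1cnnc1` differs from compound 1 on the saturated chain carbon bound to the amide-type nitrogen: 3-methylthiophen-2-yl in place of pyridin-2-yl on a saturated chain carbon bound to an amide-type nitrogen. Going by the values given here, no measured step touches this place, so the size of the step cannot be read from the series; the only change measured so far anywhere stayed within the scatter. Compound 3 is therefore expected to remain near the limit of this assay, with an estimated step of a number no higher from compound 1 to compound 3 (the limit leaves the size open). The estimate for compound 3 in this assay is 50000 nM, with a range from 20000 nM to 100000 nM.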

Compound 3, half-maximal inhibitory concentration: > 50000 nM
Compound 3 was reported as a limit; the forecaster's own chance of this, stated with the estimate: 60%; the middle value sits exactly at the limit.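

In this assay, no step can be read from compound 1 to compound 3, since each result is a limit of the assay and not a number: the limit of > 50000 nM in this assay, at which 2 of the 3 values shown sit.

The compounds shown leave open whether 3-methylthiophen-2-yl in place of pyridin-2-yl changes the read-out at all.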